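The compounds below may be only part of what the source reports. "The series", "measured", "known", "first", "only" and "open" are said of these compounds alone.

Compound 1 `Cc1ccc(S(=O)(=O)c2nc3ccccc3nc2Nc2ccc(N)cc2)cc1` gives 24600 nM in a functional assay on A549 cells (Homo sapiens) for cytotoxicity, read by MTT assay, with a stated time of 72 h; a lower number here means a stronger inhibitor, a higher number a weaker inhibitor. Compound 2 `Cc1ccc(S(=O)(=O)c2nc3ccccc3nc2Nc2cccc(N)c2)cc1` gives 1950 nM, and compound 3 `Cc1ccc(S(=O)(=O)c2nc3ccccc3nc2Nc2ccc(C(F)(F)F)cc2)cc1` gives 13500 nM. The step of a 13-fold lower number from compound 1 to compound 2 (1.10 log units; beyond the scatter) and the step of a 6.9-fold higher number from compound 2 to compound 3 (0.84 log units; beyond the scatter) lie beyond the scatter, while a 1.8-fold lower number from compound 1 to compound 3 (0.26 log units; within the scatter) does not. Compound 3 thus stands second highest of the three numbers; compound 1 is nearest to it and within the scatter, compound 2 furthest and beyond it. Compound 4 `O=S(=O)(c1ccc(Br)cc1)c1nc2ccccc2nc1Nc1ccc(C(F)(F)F)cc1` differs from compound 3 by bromo in place of methyl on an aromatic carbon, turning the (4-methylphenyl)sulfonyl into a (4-bromophenyl)sulfonyl. All three measured steps concern the group on the nitrogen, so none bears on this change. A step within the scatter is therefore expected, no change at the digits printed from compound 3 to compound 4 (within the scatter). Compound 4 is expected to give about 13500 nM, between 5000 nM and 36000 nM.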

Compound 4, half-maximal inhibitory concentration: > 50000 nM
Compound 4: no number, only a limit; the forecaster's own chance of this, stated with the estimate: 10%; at least 3.7-fold (0.56 log units) between middle value and limit.
By their numbers in this assay, from the lowest: compound 2; then compounds 3 and 1 (each within the scatter of the next). At a limit, above all of these: compound 4.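

In this assay, for the compounds shown here, bromo in place of methyl gives an at least 3.7-fold higher number from compound 3 to compound 4 (0.56 log units; beyond the scatter) and so shows that the para position of the sulfonyl-bound ring, which no earlier step touched, is not silent. This step is a minimum, since compound 4 gives no number, only a limit: the limit of > 50000 nM in this assay, at which 1 of the 4 values shown sits. As far as these compounds go, how far the number would rise past that limit stays unknown. From the compounds shown here alone, it remains open whether methoxy, chloro or an amine at this place would read like bromo or like methyl, and whether bromo would act alike with the 3-aminophenyl group of compound 2.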